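One More Methyl on the Chain of Compound 3

The source may hold more compounds than are shown below. What is called first, only, known or untested is meant among the compounds shown, and "the series" means these compounds.

Values in an ADME assay on BALB/3T3 cells (Mus musculus) for cytotoxicity, read by sulforhodamine B assay, with a stated time of 72 h (on this read-out lower numbers stand for stronger inhibition and higher numbers for weaker inhibition), for the measured compounds:
Compound 1 `CC(=O)N[C@@H](CSC(=S)NCCCC(C)CNC(=S)SC[C@H](NC(C)=O)C(=O)O)C(=O)O` gives 7990 nM
Compound 2 `CCCNC(=S)SC[C@H](NC(C)=O)C(=O)O` gives 224000 nM
Compound 3 `CCCCNC(=S)SC[C@H](NC(C)=O)C(=O)O` gives 206000 nM

Compound 3 sits within the scatter of compound 2 in this assay while compound 1 stands far lower on the numbers. Among the compounds with values here, compound 1 differs from compound 3 in more than one place, so it offers no single step for this comparison.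

Compound 4 `CCCCCNC(=S)SC[C@H](NC(C)=O)C(=O)O` differs from compound 3 by one change methyl in place of hydrogen on a saturated chain carbon, four bonds along the chain from an amide-type nitrogen and is not yet measured. Within the data shown here, only one measured step bears on it. The same replacement, made on compound 2 at three bonds along the chain from an amide-type nitrogen, gave a 1.1-fold lower number from compound 2 to compound 3 (0.04 log units; within the scatter) and so a step of similar size, none beyond the scatter, is expected in this assay for this change. Among the measured compounds shown here, a single step is slim ground, and the data hold no further member of the series to test it against. The estimated step is a 1.1-fold lower number from compound 3 to compound 4 (0.04 log units; within the scatter) in size. For compound 4 the expected value is 190000 nM with an estimated range from 110000 nM to 300000 nM in this read-out.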

Compound 4, half-maximal inhibitory concentration: 48500 nM
For compound 4 the middle estimate is 3.9-fold (0.59 log units) above the measured one; measured number below the stated range.
By their numbers in this assay, from the lowest: compound 1; then compound 4; then compounds 3 and 2 (each within the scatter of the next).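

In this assay the methyl placed on a saturated chain carbon, four bonds along the chain from an amide-type nitrogen, gives a 4.2-fold lower number from compound 3 to compound 4 (0.63 log units; beyond the scatter) and so moves the number beyond the scatter, which the same replacement three bonds along the chain did not do, giving only a 1.1-fold lower number from compound 2 to compound 3 (0.04 log units; within the scatter). The two places on the chain therefore do not answer alike to the same change, and the earlier pair alone gave no sign of this. Read as ethyl in place of hydrogen three bonds along the chain, the change gives a 4.6-fold lower number from compound 2 to compound 4 (0.66 log units; beyond the scatter), a step also beyond the scatter, so in this short series the number falls beyond the scatter only once both added carbons are present. Nothing measured here explains why the response appears at this place on the chain.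

From the compounds shown here alone, whether a longer chain such as hexyl would lower the number further or leave it level remains open. So does whether a branched chain or a terminal amine at this place would act as the added methyl does, and compound 1 cannot settle this, as it differs from compound 4 in more than one place.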